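This account rests on a few compounds, and the source may have more. Where it says the series, first, only, none or still open, it means among the compounds named here.

In a functional assay on HT-29 cells (Homo sapiens) (on this read-out higher numbers stand for an effect only at larger amounts of compound and lower numbers for an effect already at smaller amounts), compound 1 `CN1CCN(C(=O)c2cc(-c3ccccc3)sc2NC(N)=O)CC1` has no single number to start from, its entry reading "not determined" (no result reported). Compound 3 `NCCNC(=O)c1cc(-c2ccccc2)sc1NC(N)=O` changes one place on that structure: (2-aminoethyl)amino in place of 4-methylpiperazin-1-yl on a carbonyl carbon. Thus (2-aminoethyl)amino takes the place of 4-methylpiperazin-1-yl on a carbonyl carbon, while the shared core stays the same. For the measured compounds named here, no measured step shows what this kind of swap does, so no shift beyond the usual scatter is expected in this assay. Going by the values given here, the only nearby number comes from compound 2 `CN(C)C(=O)c1ccc(-c2cc(C(=O)N[C@H]3CCCNC3)c(NC(N)=O)s2)cc1`, which gives 320 nM, and the expectation leans loosely on it. Compound 3 is estimated at 1000 nM, with a likely range of 200 nM to 5000 nM.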

Compound 3, half-maximal effective concentration: 960 nM
Compound 3: middle estimate off by 1.0-fold (0.02 log units), on the high side; the range from low to high includes it.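

Compound 1 reads "not determined" (no result reported) in this assay, so no step to compound 3 can be read, and nothing available explains the result for compound 3. Going by these compounds, what replacing 4-methylpiperazin-1-yl with (2-aminoethyl)amino does in this assay stays open.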